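Allyl to phenyl on the thiosemicarbazide nitrogen: hemolysis

The source may hold more compounds than are shown below. What is called first, only, known or untested is meant among the compounds shown, and "the series" means these compounds.

Compound 1 `C=CCNC(=S)N/N=C\c1ccccc1OCc1ccc2no[n+]([O-])c2c1` in an ADME assay on cells (Erythrocyte, Homo sapiens), read by spectrophotometry and hemolysis, with a stated time of 24 h (a higher number here means a weaker inhibitor, a lower number a stronger inhibitor), gives 139 uM.
Compound 2 `[O-][n+]1onc2ccc(COc3ccccc3/C=N\NC(=S)Nc3ccccc3)cc21` reaches only a limit of this assay, > 200 uM.
Compound 3 `C=CCNC(=S)N/N=C/c1ccc(OCc2ccc3c(c2)=[N+]([O-])C(C)(C)[N+]=3[O-])cc1` likewise reaches only a limit of this assay, > 100 uM.

The change from compound 1 to compound 2 is phenyl in place of allyl on an amide-type nitrogen, and it made an at least 1.4-fold higher number from compound 1 to compound 2 (0.15 log units; that floor lies within the scatter). The same change is made on a different core, turning compound 3 into compound 4 `CC1(C)[N+]([O-])=c2ccc(COc3ccc(/C=N/NC(=S)Nc4ccccc4)cc3)cc2=[N+]1[O-]`: phenyl in place of allyl on an amide-type nitrogen. How the core of compound 3 differs from the core of compound 1 is not broken down here. Because an at least 1.4-fold higher number from compound 1 to compound 2 (0.15 log units; that floor lies within the scatter) was seen, a similar move toward a weaker inhibitor is expected here too, a step that the limit leaves unreadable from compound 3 to compound 4, though compound 3 already sits at a limit, so any step is uncertain in size. For compound 4 in this assay the estimate is 200 uM, with a range from 120 uM to 400 uM, and the result is expected most often to be reported only as a limit.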

Compound 4, concentration for 50% inhibition: < 50 uM
Compound 4: a limit, no number; the forecaster's own chance of this, stated with the estimate: 85%; middle value at least 4.0-fold (0.60 log units) from the limit.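

Phenyl in place of allyl on the amide-type nitrogen did not behave the same way on the two cores in this assay: the same change on two cores in this assay, an at least 1.4-fold higher number (0.15 log units; that floor lies within the scatter) from compound 1 to compound 2 and an at least 2.0-fold lower number (0.30 log units; that floor lies within the scatter) from compound 3 to compound 4, at least 2.8-fold (0.45 log units) apart, beyond the scatter of two such steps. The new step is an at least 2.0-fold lower number from compound 3 to compound 4 (0.30 log units; that floor lies within the scatter), and since both compounds sit at limits of the assay rather than at numbers, it gives only a direction and a smallest possible size. The two pairs therefore show that this change cannot simply be carried from one core to the other, but not how large either step truly is, nor which part of the core matters.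

Open, going by these compounds, is how a benzyl group or a longer chain such as butyl on this nitrogen would read on each core. On these data alone, whether the direction seen with compound 4 would hold on any further core also remains open.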